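Permeability notes: tert-butyl for methoxy on compound 3

This account rests on a few compounds, and the source may have more. Where it says the series, first, only, none or still open, it means among the compounds named here.

Measured so far:
compound 1 `COc1cccc(CNCCCNc2ccnc3cc(Oc4ccc(Cl)cc4)ccc23)c1O`: 317 10^-6 cm/s
compound 2 `COc1cccc(CNCCCNc2ccnc3cc(Oc4ccc(F)cc4)ccc23)c1O`: 317 10^-6 cm/s
compound 3 `COc1ccc(-c2ccc3c(NCCCNCc4cccc(OC)c4O)ccnc3c2)cc1`: 237 10^-6 cm/s

In an ADME assay for permeability, using PAMPA, with a stated time of 30 min, at pH 7.4 (a lower number here means that the compound crosses the layer more slowly, a higher number that the compound crosses the layer faster), compound 3 gives the lowest of the three numbers, but a 1.3-fold lower number from compound 1 to compound 3 (0.13 log units; within the scatter) and a 1.3-fold lower number from compound 2 to compound 3 (0.13 log units; within the scatter) both lie within the scatter, so no order among the three can be read. Compound 4 `COc1cccc(CNCCCNc2ccnc3cc(-c4ccc(C(C)(C)C)cc4)ccc23)c1O` differs from compound 3 by tert-butyl in place of methoxy on an aromatic carbon. Going by the values given here, no measured step touches this position: no change at the digits printed from compound 1 to compound 2 (within the scatter) swapped a halogen, and the steps into compound 3 replaced the whole pendant group, all without moving the number beyond the scatter. Nothing therefore points to a shift in either direction, and the step is expected to be no change at the digits printed from compound 3 to compound 4 (within the scatter). Compound 4 is estimated at 237 10^-6 cm/s, expected between 150 10^-6 cm/s and 380 10^-6 cm/s.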

Compound 4, apparent permeability: 237 10^-6 cm/s
Compound 4: middle estimate and measured number agree at the digits printed; measured number inside the range.
By their numbers in this assay, from the lowest: compounds 3, 4, 1 and 2 (each within the scatter of the next).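

In this assay, going by these compounds alone, this is the first step made at the outer aromatic carbon itself: tert-butyl, with more heavy atoms and no hydrogen-bond acceptor, replaces methoxy (no change at the digits printed from compound 3 to compound 4 (within the scatter)). The wider swaps of the whole pendant group also stay inside the scatter (a 1.3-fold lower number from compound 2 to compound 4 (0.13 log units; within the scatter); a 1.3-fold lower number from compound 1 to compound 4 (0.13 log units; within the scatter)), so neither the oxygen linker nor the substituent on this ring has yet shifted the read-out. No available evidence explains this result.

Still open, from the compounds shown here alone, is whether an amine or a carboxylic acid on this aromatic carbon would move the number beyond the scatter.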